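A few compounds are considered here, and "the series" means these few. Any claim that something is new, unique, unknown or untested is made for them only; others in the source may bear on it.

Compound 1 `C(#Cc1nc2c(s1)CN(C1CCCCC1)CC2)c1ccccc1`: in an assay on HEK293 cells for positive allosteric modulation of metabotropic glutamate receptor 5 (Homo sapiens), read by FLIPR, with a stated time of 1 h (a lower number here means that less compound is needed, a higher number that more compound is needed for the effect), compound 1 gives > 10000 nM, which is a limit of the assay rather than a number.
Compound 2 `O=C(C1CCC1)N1CCc2nc(C#Cc3ccccc3)sc2C1`: in this assay compound 2 gives > 10000 nM, again a limit of the assay.
Compound 3 `O=C(C1CCCCC1)N1CCc2nc(C#Cc3ccccc3)sc2C1`: in this assay compound 3 gives 167 nM.

Within the data shown here, compound 3 therefore stands alone as the only real number in the set; the other two values sit at the limit of > 10000 nM in this assay, at which 2 of the 3 values shown sit. The step of an at least 59-fold lower number from compound 1 to compound 3 (1.77 log units; beyond the scatter) and the step of an at least 59-fold lower number from compound 2 to compound 3 (1.77 log units; beyond the scatter) are both large, each read against that limit, while the step that the two limits leave unreadable from compound 1 to compound 2 cannot be read at all.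

Compound 4 `O=C(C1CCOCC1)N1CCc2nc(C#Cc3ccccc3)sc2C1` differs from compound 3 by oxan-4-yl in place of cyclohexyl on a carbonyl carbon. The measured step that comes closest is an at least 59-fold lower number from compound 2 to compound 3 (1.77 log units; beyond the scatter), where a smaller ring on the carbonyl carbon pushed the value out to the limit. Among the measured compounds shown here, the change to compound 4 keeps a six-membered ring of the same size and exchanges a single ring atom; no measured step covers exactly that exchange. A modest step is expected, as a 1.9-fold higher number from compound 3 to compound 4 (0.28 log units; within the scatter), most likely toward a somewhat higher number but not clearly beyond the scatter. Compound 4 is estimated to give 320 nM in this assay, within a range from 100 nM to 1500 nM.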

Compound 4, half-maximal effective concentration: 290 nM
For compound 4 the middle estimate is 1.1-fold (0.04 log units) above the measured one; low and high end bracket the measured number.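

In this assay, exchanging cyclohexyl for oxan-4-yl on the carbonyl carbon gives a 1.7-fold higher number from compound 3 to compound 4 (0.24 log units; within the scatter), so a ring oxygen and a hydrogen-bond acceptor are tolerated at this place without a change beyond the scatter. The earlier compounds had shown only that cyclohexyl on this carbonyl carbon gave a number where cyclobutyl did not; compound 4 adds that the six-membered ring there need not be carbon only, with an at least 34-fold lower number from compound 2 to compound 4 (1.53 log units; beyond the scatter). The carbonyl-linked ring also holds up against the cyclohexyl group on the ring nitrogen of compound 1, with an at least 34-fold lower number from compound 1 to compound 4 (1.53 log units; beyond the scatter), and this step, like the one before it, is read against a limit of the assay rather than a number: the limit of > 10000 nM in this assay, at which 2 of the 4 values shown sit.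

What the compounds shown leave open is whether a ring nitrogen, as in piperidin-4-yl, would be accepted in the place of the oxygen as well. Also open, on these data alone, is where between cyclobutyl and the six-membered rings the number appears, which cyclopentyl on the same carbonyl carbon would address, and whether an open chain such as pentyl could stand in for a ring at all.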